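Fluorine on the indazole of a cinnamic acid series

This account rests on a few compounds, and the source may have more. Where it says the series, first, only, none or still open, it means among the compounds named here.

Among the measured compounds shown here, compound 2 `CC/C(=C(/c1ccc(/C=C/C(=O)O)cc1)c1cc(C)c2[nH]ncc2c1)c1ccccc1` is the only member of this set with a number in a functional assay on MCF7 cells (Homo sapiens) for cytotoxicity, read by CellTiter-Glo, with a stated time of 5 days (a lower number here means a stronger inhibitor, a higher number a weaker inhibitor), where compound 2 gives 59 nM. Its relative compound 1 `CC/C(=C(/c1ccc(/C=C/C(=O)O)cc1)c1ccc2[nH]nc(C)c2c1)c1ccccc1` reaches only a limit of the assay: in this assay compound 1 gives > 1000 nM (the limit of > 1000 nM in this assay, at which 1 of the 2 values shown sits). For the measured compounds named here, the one measured step, an at least 16-fold lower number from compound 1 to compound 2 (1.22 log units; beyond the scatter), is therefore known only as a bound.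

Compound 3 `CC/C(=C(/c1ccc(/C=C/C(=O)O)cc1)c1ccc2[nH]nc(F)c2c1)c1ccccc1` changes the same ring: 3-fluoro-1H-indazol-5-yl in place of 7-methyl-1H-indazol-5-yl on a double-bonded chain carbon bound to an aromatic carbon and a double-bonded chain carbon. Going by the values given here, its 3-fluoro-1H-indazol-5-yl group follows the naming of the 3-methyl-1H-indazol-5-yl group of compound 1 rather than the 7-methyl-1H-indazol-5-yl group of compound 2, but fluorine is not methyl and no step from compound 1 or compound 2 to a fluorinated analogue exists. The step from compound 1 to compound 2 bears on it only loosely, so a weakening beyond the scatter is expected, though smaller than that bound. The expected change from compound 2 to compound 3 is a 5.1-fold higher number from compound 2 to compound 3 (0.71 log units; beyond the scatter). Compound 3 is estimated at 300 nM, within a range from 80 nM to 1500 nM.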

Compound 3, half-maximal inhibitory concentration: 5 nM
Estimate against measurement, compound 3: 60-fold (1.78 log units) above; the measured number lies below the stated range.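

In this assay, among the compounds shown here, the 3-fluoro-1H-indazol-5-yl group does far better than the 7-methyl-1H-indazol-5-yl group, with a 12-fold lower number from compound 2 to compound 3 (1.07 log units; beyond the scatter), so the earlier compounds' ranking of the two methyl groups did not mark the limit of what this ring can give. Fluoro in place of methyl on the same aromatic carbon gives an at least 200-fold lower number from compound 1 to compound 3 (2.30 log units; beyond the scatter), the first comparison in this set in which the substituent changes while its place on the ring stays the same, and it shows that the poor result of compound 1 does not extend to every group on that carbon. The size of that change remains a bound, as compound 1 stands at a limit of the assay: the limit of > 1000 nM in this assay, at which 1 of the 3 values shown sits.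

The compounds shown leave open whether chloro, a nitrile or an ethyl group on that same carbon would match fluoro, and how the plain 1H-indazol-5-yl group compares with all of these. They also leave open whether a 7-fluoro-1H-indazol-5-yl group, or a single indazole carrying both the 3-fluoro and the 7-methyl group, would give a lower number still.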